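Moving the halogen on the ether ring: fluoro to chloro

This account rests on a few compounds, and the source may have more. Where it says the series, first, only, none or still open, it means among the compounds named here.

Measured compounds:
- compound 1 `O=C(O)C[C@@H]1CCCN1c1ccc(Oc2ccccc2F)cc1`: 150 nM
- compound 2 `CC(C)(C)c1ccccc1Oc1ccc(N2CCC[C@H]2CC(=O)O)cc1`: 6500 nM

Compound 1 gives the lowest number of the two in a functional assay on cells for agonist activity at Free fatty acid receptor 1 (Homo sapiens), read by FLIPR and calcium flux, with a stated time of 100 s; on this read-out higher numbers stand for an effect only at larger amounts of compound and lower numbers for an effect already at smaller amounts; its nearest neighbour is compound 2, and a 43-fold higher number from compound 1 to compound 2 (1.64 log units; beyond the scatter) separates them. Compound 3 `O=C(O)C[C@@H]1CCCN1c1ccc(Oc2ccc(Cl)cc2)cc1` has not been measured. It differs from compound 1 in one place: 4-chlorophenyl in place of 2-fluorophenyl on an oxygen on an aromatic ring. Within the data shown here, the only measured step, from compound 1 to compound 2, exchanges the fluoro for tert-butyl on the same ring carbon and says nothing about a chlorine at the 4-position of that ring, so it bears on the present change only loosely. Among the measured compounds shown here, no measured pair tests a halogen at another position. With that, the expected step of a 1.3-fold lower number from compound 1 to compound 3 (0.10 log units; within the scatter) is small, within the scatter, in either direction. Compound 3 is therefore estimated at 120 nM, with a range from 30 nM to 500 nM.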

Compound 3, half-maximal effective concentration: 290 nM
Compound 3: the middle estimate sits 2.4-fold (0.38 log units) below what was measured; the measured number falls inside the stated range.
By their numbers in this assay, from the lowest: compounds 1 and 3 (each within the scatter of the next); then compound 2.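

In this assay, placing 4-chlorophenyl in place of 2-fluorophenyl on an oxygen on an aromatic ring gives a 1.9-fold higher number from compound 1 to compound 3 (0.29 log units; within the scatter), so this change leaves the number within the scatter. Among these compounds, the earlier step, a 43-fold higher number from compound 1 to compound 2 (1.64 log units; beyond the scatter), showed only that this ring does not tolerate every replacement; compound 3 now shows that one ring bearing a different halogen, attached at a different ring carbon, can take the place of the 2-fluorophenyl group without a step beyond the scatter. No measurement here offers an explanation for this result.

Going by these compounds, the halogen and its place on the ring change together in this single step, so the contribution of each alone remains open. On these data alone, it also remains open whether a group other than a halogen on this ring, such as methoxy or nitrile, would keep the number close to that of compound 1.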